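A few compounds are considered here, and "the series" means these few. Any claim that something is new, unique, unknown or untested is made for them only; others in the source may bear on it.

Measured compounds:
compound 1 `CC(C)C[C@H](N)c1cc(C(F)(F)F)ccc1N1CCN(C(=O)COc2ccc3ccccc3c2)CC1` — 2000 nM
compound 2 `Cc1ccc(OCC(=O)N2CCN(c3ccc(C(F)(F)F)cc3[C@@H](N)CC(C)C)CC2)c(C)c1` — 4000 nM
compound 3 `CC(C)C[C@H](N)c1cc(C(F)(F)F)ccc1N1CCN(C(=O)COc2cccc3ccccc23)CC1` — 2600 nM

Among the measured compounds shown here, in an assay on HEK293 cells for displacement of a labelled ligand from Melanocortin receptor 4 (Homo sapiens) (a lower number here means a stronger inhibitor, a higher number a weaker inhibitor), compound 1 gives 2000 nM, the low end of the three numbers, but a 1.3-fold higher number from compound 1 to compound 3 (0.11 log units; within the scatter) and a 2.0-fold higher number from compound 1 to compound 2 (0.30 log units; within the scatter) both fall within the scatter, so no compound is set apart from the others.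

All three measured compounds share the same core and differ only in the group carried on the oxygen on a saturated carbon: naphthalen-2-yl, 2,4-dimethylphenyl or naphthalen-1-yl. The steps of a 2.0-fold higher number from compound 1 to compound 2 (0.30 log units; within the scatter), a 1.3-fold higher number from compound 1 to compound 3 (0.11 log units; within the scatter) and a 1.5-fold lower number from compound 2 to compound 3 (0.19 log units; within the scatter) all stay within the scatter, so swapping one aromatic group for another at that position has left the number essentially unchanged.

Compound 4 `Cc1cc(CC(C)C(=O)N2CCN(c3ccc(C(F)(F)F)cc3[C@@H](N)CC(C)C)CC2)ccc1Cl` departs further: 1-(4-chloro-3-methylbenzyl)ethyl in place of ((naphthalen-2-yl)oxy)methyl on a carbonyl carbon. For the measured compounds named here, the oxygen and its hydrogen-bond acceptor are lost and a single ring replaces two, which none of the measured steps covers. With the aryl swaps inert, a modest drift is expected rather than a sharp move, and the loss of the acceptor is taken as a mild risk of a higher number. Compound 4 is therefore expected to show a 1.5-fold higher number from compound 1 to compound 4 (0.18 log units; within the scatter), giving an estimate of 3000 nM with a range of 800 nM to 12000 nM.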

Compound 4, inhibition constant: 71 nM
The estimate for compound 4 lay 42-fold (1.63 log units) above the measured number; measured number outside the range, below it.
By their numbers in this assay, from the lowest: compound 4; then compounds 1, 3 and 2 (each within the scatter of the next).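

In this assay this position is not inert after all: the change on the carbonyl carbon gives a 28-fold lower number from compound 1 to compound 4 (1.45 log units; beyond the scatter) and a 37-fold lower number from compound 3 to compound 4 (1.56 log units; beyond the scatter) and a 56-fold lower number from compound 2 to compound 4 (1.75 log units; beyond the scatter), all of them beyond the scatter, whereas swapping one aromatic group for another on the oxygen had moved nothing beyond it. The sensitivity therefore appears only when the whole ((aryl)oxy)methyl unit gives way to 1-(4-chloro-3-methylbenzyl)ethyl, and the step from compound 2, whose group also carries a single aromatic ring, shows that going from two rings to one is not needed for the number to fall. No measurement available here bears on why the number falls.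

The change replaces the oxygen, adds a methyl branch and brings in the chlorine and ring methyl all at once, and the compounds shown do not separate these parts. As far as these compounds go, whether a (4-chloro-3-methylphenoxy)methyl group would reach a number like that of compound 4, or a plain benzyl group would lose it, remains open.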